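The compounds below may be only part of what the source reports. "The series", "measured", "known", "first", "only" and "open" are said of these compounds alone.

Three compounds of this series have numbers in a functional assay with Mus musculus as the target; on this read-out higher numbers stand for an effect only at larger amounts of compound and lower numbers for an effect already at smaller amounts. Compound 1 `C=CCn1c(=O)n([C@H]2CO[C@@H](CO)C2)c2nc(N)nc(O)c21` gives 272 uM. Compound 2 `CCOC(=O)Cn1c(=O)n(C2OC(CO)[C@@H](O)[C@H]2O)c2nc(N)nc(O)c21` gives 630 uM. Compound 3 `C=CCn1c(=S)n(C2OC(COC(C)=O)[C@H]3OC(C)(C)O[C@@H]23)c2nc(N)nc(O)c21` gives 50 uM. Compound 2 thus carries the highest of the three numbers; compound 1 stands nearest to it and compound 3 furthest, and both gaps lie beyond the usual scatter. Compounds 1 and 3 differ from compound 2 in more than one place at once, so their numbers cannot be read as the result of any single change.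

Compound 4 `Cn1c(=O)n(C2OC(CO)[C@@H](O)[C@H]2O)c2nc(N)nc(O)c21` has not yet been measured in this assay. It differs from compound 2 in one place only: hydrogen in place of ethoxycarbonyl on a saturated chain carbon bound to an aromatic nitrogen. For the measured compounds named here, no measured pair isolates this change, and the other compounds vary elsewhere as well, so nothing measured points in a direction. The step from compound 2 to compound 4 in this assay is expected to be a 1.6-fold lower number from compound 2 to compound 4 (0.20 log units; within the scatter), a modest move that may well stay within the scatter. Compound 4 is accordingly estimated to give about 400 uM in this assay, with the expected range running from 120 uM to 1500 uM.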

Compound 4, concentration for half-maximal effect: 120 uM
Estimate against measurement, compound 4: 3.3-fold (0.52 log units) above; the measured number falls inside the stated range.
By their numbers in this assay, from the lowest: compound 3; then compound 4; then compound 1; then compound 2.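

For the compounds shown here, the step in this assay is the first reading of a single change: hydrogen in place of ethoxycarbonyl on a saturated chain carbon bound to an aromatic nitrogen gives a 5.3-fold lower number from compound 2 to compound 4 (0.72 log units; beyond the scatter) and lies beyond the scatter. The position therefore responds to substitution. This could not be read from compounds 1 and 3, which differ from compound 2 in more than one place at once. The effect in this organism also does not depend on the ethoxycarbonyl group, since the plain methyl of compound 4, reached by removing those 5 heavy atoms with no heavy atom entering, still gives a number and a lower one; nothing at hand explains the size of this step.

This single pair cannot show whether the shift follows from losing the ester as such or from the smaller substituent, and a carboxylic acid or a primary amide on the same methylene, or an ethyl or propyl chain in place of the methyl, would separate the two. The allyl group of compounds 1 and 3 also remains unplaced on the core of compound 4, so its standing against methyl cannot be read.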